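Trading an aminophenyl for a fluorophenyl on a urea

The source may hold more compounds than are shown below. What is called first, only, known or untested is meant among the compounds shown, and "the series" means these compounds.

Of the compounds shown here, three sharing one core have been measured in a physicochemical assay for solubility, at pH 7.4; a higher number here means a more soluble compound, a lower number a less soluble compound. Compound 1 `Cc1cc(NC(=O)Nc2cc(F)ccc2F)c2ccccc2n1` gives 500 nM, compound 2 `Cc1ccc(NC(=O)Nc2cc(C)nc3ccccc23)cc1` gives 1300 nM, and compound 3 `Cc1cc(NC(=O)Nc2ccc(N)cc2)c2ccccc2n1` gives 18500 nM. Within the data shown here, compound 3 therefore stands highest of the three: compound 2 is the nearest, and the single measured step, a 14-fold higher number from compound 2 to compound 3 (1.15 log units; beyond the scatter), shows how much an amino group in place of a methyl on the aromatic carbon lifted the number. Compound 1, which carries the 2,5-difluorophenyl, sits furthest below compound 3.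

The next compound, compound 4 `Cc1cc(NC(=O)Nc2ccccc2F)c2ccccc2n1`, reverses that kind of change and goes further. Its difference from compound 3 is 2-fluorophenyl in place of 4-aminophenyl on an amide-type nitrogen. Among the measured compounds shown here, the only step that bears on it is the one from compound 2 to compound 3, and it was large; compound 4 gives up the amino group entirely, so a drop at least as large as that step is expected. Compound 1, with its 2,5-difluorophenyl, and compound 2, with its 4-methylphenyl, give the lower values that compound 4 is expected to approach. The step of a 21-fold lower number from compound 3 to compound 4 (1.31 log units; beyond the scatter) is the expected move in this assay, placing compound 4 at an estimated 900 nM, within a range of 300 nM to 3000 nM.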

Compound 4, solubility: 3800 nM
For compound 4 the middle estimate is 4.2-fold (0.63 log units) below the measured one, and the stated range ends below it.
By their numbers in this assay, from the lowest: compound 1; then compound 2; then compound 4; then compound 3.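

At this place, on an amide-type nitrogen, the 4-aminophenyl is not the only ring that gives a high number in this assay: the step of a 4.9-fold lower number from compound 3 to compound 4 (0.69 log units; beyond the scatter) is modest, and the 2-fluorophenyl, with 0 hydrogen-bond donors, still stands above the 4-methylphenyl, as the step of a 2.9-fold higher number from compound 2 to compound 4 (0.47 log units; beyond the scatter) shows. The fluoro count on this ring also makes a measurable difference, since the step of a 7.6-fold higher number from compound 1 to compound 4 (0.88 log units; beyond the scatter) comes with hydrogen in place of fluoro on an aromatic carbon, so the 2,5-difluorophenyl and the 2-fluorophenyl do not read alike. Nothing measured here accounts for any of these steps.

As far as these compounds go, whether the order of 4-aminophenyl, 2-fluorophenyl and 4-methylphenyl holds for a ring carrying a hydroxyl, a carboxylic acid or a morpholine remains open. Among these compounds, also open is how a plain phenyl ring would read at this place, which would set the single fluoro of compound 4 against hydrogen alone.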